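Amide-nitrogen heteroaryl variation in a two-compound efficacy series

The source may report more compounds than this note shows. Statements on the series, on what has been measured and on what is new or still open speak of the compounds shown alone.

Compound 1 `CC(C)[C@H](C(=O)Nc1ccc(F)cn1)c1ccc(Cl)cc1` is the reference point here. Within the data shown here, in a functional assay on CHO cells for agonist activity at Free fatty acid receptor 2 (Homo sapiens), read by cAMP accumulation (on this read-out lower numbers stand for smaller maximal responses and higher numbers for larger maximal responses), compound 1 gives 93%, the lower of the two numbers so far. Compound 2 `CC(C)C(C(=O)Nc1cnccn1)c1ccc(Cl)cc1`, measured in the same run, gives 115%, which lies above compound 1 by more than the usual scatter. Compound 3 `CC(C)[C@H](C(=O)Nc1ncc[nH]1)c1ccc(Cl)cc1` is not yet measured; it differs from compound 1 by 1H-imidazol-2-yl in place of 5-fluoropyridin-2-yl on an amide-type nitrogen. Among the measured compounds shown here, no measured pair shows this change, so its effect on the maximal response is open. The expected step from compound 1 to compound 3 is a number 2 percentage points higher from compound 1 to compound 3 (within the scatter), small and within the scatter. Compound 3 is thus estimated at 95%, with a range from 70% to 118%.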

Compound 3, largest response reached (reported as efficacy), in percent of the reference or control that the assay uses: 55%
For compound 3 the middle estimate is 40 percentage points above the measured one; measured number below the stated range.
By their numbers in this assay, from the lowest: compound 3; then compound 1; then compound 2.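

Position notes: at the amide-type nitrogen, the heteroaryl group is not interchangeable in this assay, since 1H-imidazol-2-yl in place of 5-fluoropyridin-2-yl gives a number 38 percentage points lower from compound 1 to compound 3 (beyond the scatter) on the same core. This single step swaps a six-membered aromatic ring for a five-membered one and also adds a hydrogen-bond donor, so the two differences remain confounded. No available data account for the fall.

Ring size and the donor remain unseparated. A 1-methylimidazol-2-yl or thiazol-2-yl group at this nitrogen could help to pull them apart.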